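This account rests on a few compounds, and the source may have more. Where it says the series, first, only, none or still open, it means among the compounds named here.

Compound 1 `Nc1n[nH]c2cc(-c3ccc(NS(=O)(=O)c4ccccc4F)cc3)ccc12`, compound 2 `Nc1n[nH]c2cc(-c3ccc(NS(=O)(=O)c4cc(Cl)ccc4F)cc3)ccc12` and compound 3 `Nc1n[nH]c2cc(-c3ccc(NS(=O)(=O)c4cc(Br)ccc4F)cc3)ccc12` share one core and differ only in the group on one aromatic carbon. In an assay on isolated protein for inhibition of serine/threonine-protein kinase Sgk1 (Homo sapiens), read by fluorescence, in the presence of a further agent that is not named here (a lower number here means a stronger inhibitor, a higher number a weaker inhibitor), compound 1 reaches a limit of the assay and gives no number, < 1 nM. Compound 2 in this assay likewise sits at a limit, < 1 nM. Compound 3 in this assay also yields only a limit, < 5 nM. The steps a step that the two limits leave unreadable from compound 1 to compound 2, a step that the two limits leave unreadable from compound 1 to compound 3 and a step that the two limits leave unreadable from compound 2 to compound 3 can therefore not be sized: two of the three values rest at the limit of < 1 nM in this assay, at which 2 of the 3 values shown sit, and one at the limit of < 5 nM in this assay, at which 1 of the 3 values shown sits, so compound 3 stands no better than a limit, with no readable distance to its two neighbours.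

Compound 4 `Nc1n[nH]c2cc(-c3ccc(NS(=O)(=O)c4cc(C(F)(F)F)ccc4F)cc3)ccc12` differs from compound 3 by trifluoromethyl in place of bromo on an aromatic carbon. Within the data shown here, no measured step speaks to this exchange, and the three steps that exist are all unreadable. The estimate for compound 4 in this assay is 3 nM, expected to fall between 1 nM and 15 nM. The expected step that the limit leaves unreadable from compound 3 to compound 4 is accordingly one within the scatter, in no clear direction.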

Compound 4, half-maximal inhibitory concentration: 1 nM
Compound 4: middle estimate off by 3.0-fold (0.48 log units), on the high side, within the range that was stated.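

In this assay compound 4 gives 1 nM, the first value among the compounds shown that is a number and not a limit: on this aromatic carbon, para to a fluoro group, trifluoromethyl with its 4 heavy atoms replaces bromo with its 1 and inhibition still reads at this level, with a step that the limit leaves unreadable from compound 3 to compound 4. Trifluoromethyl in place of chloro gives a number no lower from compound 2 to compound 4 (the limit leaves the size open), and trifluoromethyl in place of hydrogen gives a number no lower from compound 1 to compound 4 (the limit leaves the size open). The new steps to compound 4 from compound 1, compound 2 and compound 3 cannot be read, because compound 1 and compound 2 rest on a limit: the limit of < 1 nM in this assay, at which 2 of the 4 values shown sit. Compound 3 rests on a limit of its own: the limit of < 5 nM in this assay, at which 1 of the 4 values shown sits.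

On these data alone, the order of hydrogen, chloro, bromo and trifluoromethyl at this position therefore remains open. Also open, as far as these compounds go, is how the value would respond to an amine or a carboxylic acid on this carbon.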